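The source may hold more compounds than are shown below. What is called first, only, known or untested is meant among the compounds shown, and "the series" means these compounds.

Compound 1, `OC[C@@H]1[C@@H]2COC[C@H]2C[C@H]1n1cnc2c(Cl)ncnc21`. In an ADME assay on L1210/0 cells (Mus musculus) for cytotoxicity, with a stated time of 48 h (on this read-out higher numbers stand for weaker inhibition and lower numbers for stronger inhibition), compound 1 gives > 200000 nM, which is a limit of the assay and not a number.

Compound 2, `O=c1[nH]c(=O)n([C@H]2C[C@H](O)[C@@H](CO)O2)cc1C#CCO`. In this assay compound 2 gives > 200000 nM, again a limit of the assay and not a number.

Compound 3, `CC1(C)[C@@H](CCCO)C[C@H]1n1cnc2c(Cl)nc(N)nc21`. In this assay compound 3 gives > 200000 nM, also a limit of the assay and not a number.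

Compound 2 therefore stands nowhere in particular among these three: every value shown is a limit, and all three sit at the same one, (the limit of > 200000 nM in this assay, at which 3 of the 3 values shown sit). No distance between any two of them can be read, and none of them can be called stronger or weaker than another.

The unmeasured compound 4, `O=c1[nH]c(=O)n([C@H]2C[C@H](O)[C@@H](CO)O2)cc1C1SCCS1`, is built from compound 2 by one change: a group of 5 heavy atoms (3 carbon, 2 sulfur; one five-membered non-aromatic ring with 2 hetero atoms) in place of a group of 4 heavy atoms (3 carbon, 1 oxygen; no ring), on an aromatic carbon. Going by the values given here, no step between measured compounds is available, so the size of this kind of change on this read-out is unknown here. With the starting point resting at a limit, the expectation is that compound 4 also stays at or beyond that limit, with no movement beyond the scatter that can be seen. Compound 4 is thus estimated at 200000 nM, within 50000 nM to 1000000 nM. The step this estimate means, a number no higher from compound 2 to compound 4 (the limit leaves the size open), is expected to be one that the assay cannot resolve.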

Compound 4, half-maximal inhibitory concentration: > 200000 nM
Compound 4 gave a limit, no number; the forecaster's own chance of this, stated with the estimate: 85%; the middle value sits exactly at the limit.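

In this assay compound 4 gives > 200000 nM, a limit of the assay and not a number. Compound 2 also rests at a limit, so the step between compound 2 and compound 4 cannot be read. Left open is how any of the four compounds ranks against the others, since all share one value: the limit of > 200000 nM in this assay, at which 4 of the 4 values shown sit.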